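Hydroxy on the Ketone-Side Ring of a Chalcone Series

The source may hold more compounds than are shown below. What is called first, only, known or untested is meant among the compounds shown, and "the series" means these compounds.

Measured compounds:
- compound 1, `O=C(/C=C/c1cccc(OCc2ccccc2)c1)c1ccc(Br)cc1`, 6500 nM
- compound 2, `O=C(/C=C/c1cccc(OCc2ccccc2)c1)c1cccc(Br)c1`, 7900 nM
- compound 3, `O=C(/C=C/c1cccc(OCc2ccccc2)c1)c1ccccc1`, 9800 nM

All three share a core and differ only in the ring attached to the carbonyl carbon. In a functional assay on MCF7 cells (Homo sapiens) for cytotoxicity, read by MTT assay, with a stated time of 68 h (on this read-out higher numbers stand for weaker inhibition and lower numbers for stronger inhibition), compound 3 gives the highest of the three numbers, yet its steps to the others are small: a 1.5-fold higher number from compound 1 to compound 3 (0.18 log units; within the scatter) and a 1.2-fold higher number from compound 2 to compound 3 (0.09 log units; within the scatter), both within the scatter, so the three compounds cannot be told apart on these numbers.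

Compound 4, `O=C(/C=C/c1cccc(OCc2ccccc2)c1)c1ccc(O)cc1`, has not yet been measured. It differs from compound 3 by hydroxy in place of hydrogen on an aromatic carbon.

Among the measured compounds shown here, the steps that bear on this change are those at the same ring: removing bromo, a 1.5-fold higher number from compound 1 to compound 3 (0.18 log units; within the scatter) and a 1.2-fold higher number from compound 2 to compound 3 (0.09 log units; within the scatter), each within the scatter. For the measured compounds named here, no measured step involves hydroxy, so there is nothing to show that a group on this ring shifts the number beyond the scatter. For compound 4 the expected step is therefore a 1.1-fold lower number from compound 3 to compound 4 (0.04 log units; within the scatter), with no direction beyond the scatter. The estimate for compound 4 in this assay is 9000 nM, in the range 4000 nM to 20000 nM.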

Compound 4, half-maximal inhibitory concentration: 2800 nM
The estimate for compound 4 lay 3.2-fold (0.51 log units) above the measured number; measured number below the stated range.
By their numbers in this assay, from the lowest: compound 4; then compounds 1, 2 and 3 (each within the scatter of the next).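

Hydroxy is the first group on the ring attached to the carbonyl carbon to move the number beyond the scatter in this assay, with a 3.5-fold lower number from compound 3 to compound 4 (0.54 log units; beyond the scatter), whereas neither bromo compound could be told apart from the unsubstituted ring. The step also holds against both bromo compounds, with a 2.3-fold lower number from compound 1 to compound 4 (0.37 log units; beyond the scatter) and a 2.8-fold lower number from compound 2 to compound 4 (0.45 log units; beyond the scatter). So this ring is not indifferent to what it carries, and the identity of the group matters, since hydroxy stands apart from both bromo and hydrogen. No supporting measurement bears on what lies behind these steps.

From the compounds shown here alone, whether a methoxy group or an amine in the same place would give a step of similar size remains open. So does whether hydroxy would keep its step at another place on this ring.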